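Replacing cyano with (trifluoromethyl)carbonyl: working notes

A few compounds are considered here, and "the series" means these few. Any claim that something is new, unique, unknown or untested is made for them only; others in the source may bear on it.

Measured so far in an ADME assay on the whole organism (plasma, strain Sprague-Dawley) for pharmacokinetics, with Rattus norvegicus as the target, at a dose of 5 mg/kg by the oral route; on this read-out lower numbers stand for lower exposure and higher numbers for higher exposure at the dose given
- Compound 1 (`CN(C)CC[C@H](CSc1ccccc1)Nc1ccc(S(=O)(=O)NC(=O)c2ccc(N3CCN(Cc4ccccc4-c4ccc(Cl)cc4)CC3)cc2)cc1`) : "not determined" (no result reported)
- Compound 2 (`CN(C)CC[C@H](CSc1ccccc1)Nc1ccc(S(=O)(=O)NC(=O)c2ccc(N3CCN(Cc4ccccc4-c4ccc(Cl)cc4)CC3)cc2)cc1S(=O)(=O)C(F)(F)F`) : 747 ng.h/mL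
- Compound 3 (`CN(C)CC[C@H](CSc1ccccc1)Nc1ccc(S(=O)(=O)NC(=O)c2ccc(N3CCN(Cc4ccccc4-c4ccc(Cl)cc4)CC3)cc2)cc1C#N`) : 1740 ng.h/mL

Compound 3 stands highest of the two numbers. Among the measured compounds shown here, the only measured step bearing on the next change is a 2.3-fold higher number from compound 2 to compound 3 (0.37 log units; beyond the scatter) with cyano in place of (trifluoromethyl)sulfonyl on an aromatic carbon. Compound 4 (`CN(C)CC[C@H](CSc1ccccc1)Nc1ccc(S(=O)(=O)NC(=O)c2ccc(N3CCN(Cc4ccccc4-c4ccc(Cl)cc4)CC3)cc2)cc1C(=O)C(F)(F)F`) carries (trifluoromethyl)carbonyl in place of cyano on an aromatic carbon. For the measured compounds named here, this change leaves cyano, as the measured step entered it, so that step read in reverse is the closest guide, although no carbonyl analogue has been measured. In this assay an estimated step of a 2.0-fold lower number from compound 3 to compound 4 (0.31 log units; beyond the scatter) is expected, toward a lower number and of similar size. Compound 4 is estimated at 850 ng.h/mL with an expected range from 300 ng.h/mL to 2000 ng.h/mL for now.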

Compound 4, area under the concentration-time curve: 1080 ng.h/mL
For compound 4 the middle estimate is 1.3-fold (0.10 log units) below the measured one; measured number inside the range.
By their numbers in this assay, from the lowest: compounds 2, 4 and 3 (each within the scatter of the next, the first and the last beyond it).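

In this assay the exchange on this aromatic carbon gives a 1.6-fold lower number from compound 3 to compound 4 (0.21 log units; within the scatter) and, set against the (trifluoromethyl)sulfonyl group, a 1.4-fold higher number from compound 2 to compound 4 (0.16 log units; within the scatter) so compound 4 cannot be separated from either compound, although compound 2 and compound 3 stand apart. The three groups therefore do not form a clean order at this position. Nothing at hand accounts for these exposures.

Going by these compounds, how an amine or a carboxylic acid on this aromatic carbon would read in this assay stays open. On these data alone, whether a longer chain in that place would stay within this range also remains open.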